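The source may report more compounds than this note shows. Statements on the series, on what has been measured and on what is new or still open speak of the compounds shown alone.

Among the compounds with values here, compound 3 `Cc1c(C(C)C)c(=O)on1C(=O)N1CC=CC1` stands highest of the two numbers so far obtained in an assay (strain Wistar) for inhibition of Hormone-sensitive lipase (Rattus norvegicus), read by spectrophotometry; on this read-out higher numbers stand for weaker inhibition and lower numbers for stronger inhibition: compound 3 gives 72 nM. Its nearest neighbour, compound 2 `Cc1c(C(C)C)c(=O)on1C(=O)N1CCCC1`, gives 15 nM in this assay, and a 4.8-fold higher number from compound 2 to compound 3 (0.68 log units; beyond the scatter). Within the data shown here, for compound 1 `Cc1c(C(C)C)c(=O)on1C(=O)N(C)CCC#N` only a limit is reported, > 1000 nM, the one value sitting at the limit of > 1000 nM in this assay, at which 1 of the 3 values shown sits. Compound 4 `Cc1c(C(C)C)c(=O)on1C(=O)N1CCNCC1` is not yet measured; compared with compound 3, (a group of 6 heavy atoms (4 carbon, 2 nitrogen; one six-membered non-aromatic ring with 2 hetero atoms) in place of a group of 5 heavy atoms (4 carbon, 1 nitrogen; one five-membered non-aromatic ring with 1 hetero atom), on a carbonyl carbon). Of the measured steps, an at least 13-fold lower number from compound 1 to compound 3 (1.14 log units; beyond the scatter) and an at least 66-fold lower number from compound 1 to compound 2 (1.82 log units; beyond the scatter) bear on this change most directly, since in each of them a five-membered ring with one nitrogen replaced an acyclic group carrying two nitrogens, and both steps were large. Compound 4 carries a second nitrogen again, now within a ring, and the expectation is therefore a step upward in number, modest to large rather than within the scatter. Compound 4 is expected to give about 300 nM in this assay, estimated to lie between 60 nM and 1500 nM. The expected step would be a 4.2-fold higher number from compound 3 to compound 4 (0.62 log units; beyond the scatter).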

Compound 4, half-maximal inhibitory concentration: > 1000 nM
Compound 4 was reported as a limit (the forecaster's own chance of this, stated with the estimate: 25%); at least 3.3-fold (0.52 log units) between middle value and limit.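

At this place, on a carbonyl carbon whose other neighbour is an aromatic nitrogen, piperazin-1-yl is tolerated far less well than either five-membered ring: the printed steps are an at least 13-fold higher number from compound 3 to compound 4 (1.14 log units; beyond the scatter) and an at least 66-fold higher number from compound 2 to compound 4 (1.82 log units; beyond the scatter). Among the earlier compounds, only compound 1, with its open chain, sat at a limit in this assay, whereas compound 4 shows that a ring on this carbonyl does not by itself keep the number low. Compound 1 and compound 4 both stand at a limit, so the step between them cannot be read: the limit of > 1000 nM in this assay, at which 2 of the 4 values shown sit.

The compounds shown do not separate the larger ring from the second ring nitrogen, a question that piperidin-1-yl, a six-membered ring with a single nitrogen, would address. Going by these compounds, how far past its limit compound 4 lies also remains open.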